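The source may report more compounds than this note shows. Statements on the series, on what has been measured and on what is new or still open speak of the compounds shown alone.

Compound 1 `COc1ccc2[nH]c(-c3cccc(F)c3)cc(=O)c2c1O` gives 80 nM in a functional assay on NCI-H460 cells (Homo sapiens) for cytotoxicity, read by MTT assay, with a stated time of 48 h; a higher number here means a weaker inhibitor, a lower number a stronger inhibitor. Compound 2 `COc1ccc2[nH]c(-c3ccc(F)cc3)cc(=O)c2c1O` gives 8800 nM in this assay, and the change from compound 1 to compound 2, (4-fluorophenyl in place of 3-fluorophenyl on an aromatic carbon), made a 110-fold higher number from compound 1 to compound 2 (2.04 log units; beyond the scatter). Compound 3 `COc1cc2c(=O)cc(-c3cccc(F)c3)[nH]c2cc1O` gives 4800 nM in this assay; the difference between the core of compound 1 and the core of compound 3 is not broken down here, and the two values show compound 3 well weaker than compound 1 and close to compound 2. Compound 4 `COc1cc2c(=O)cc(-c3ccc(F)cc3)[nH]c2cc1O` has not yet been measured in this assay. It differs from compound 3 by 4-fluorophenyl in place of 3-fluorophenyl on an aromatic carbon, the same change seen between compound 1 and compound 2. Compound 4 is expected to show a step of a 7.3-fold higher number from compound 3 to compound 4 (0.86 log units; beyond the scatter), smaller than the earlier one because compound 3 already starts from 4800 nM. The estimate for compound 4 in this assay is 35000 nM, between 7000 nM and 150000 nM.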

Compound 4, half-maximal inhibitory concentration: > 100000 nM
Compound 4: a limit, no number; the forecaster's own chance of this, stated with the estimate: 30%; middle value at least 2.8-fold (0.45 log units) away from the limit.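

In this assay, 4-fluorophenyl in place of 3-fluorophenyl again gave a large step on the core of compound 3 (an at least 20-fold higher number from compound 3 to compound 4 (1.31 log units; beyond the scatter)), so the direction of the change carried over between the two cores shown. Compound 4 gives > 100000 nM, which is a limit of the assay and not a number. The data therefore do not show whether the change is equally large on both cores: the same change on two cores in this assay, a 110-fold higher number (2.04 log units; beyond the scatter) from compound 1 to compound 2 and an at least 20-fold higher number (1.31 log units; beyond the scatter) from compound 3 to compound 4; the limit leaves it open whether they differ

Every compound shown carries fluorine on the phenyl ring, which leaves open whether the same step would appear with chlorine or a nitrile in those two places. Also open, on these data alone, is whether it would persist on a core bearing an amine in place of the hydroxyl.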